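Working notes: from compound 1 to compound 3

The compounds below may be only part of what the source reports. "The series", "measured", "known", "first", "only" and "open" are said of these compounds alone.

Values in a functional assay on U-373MG ATCC cells (Homo sapiens) for inhibition, read by MTT assay, with a stated time of 72 h; on this read-out lower numbers stand for stronger inhibition and higher numbers for weaker inhibition:
- Compound 1 `CC(C)NC(=S)NC1CC(C)(C)Oc2ccc(Cl)cc21`: 57000 nM
- Compound 2 `CC1(C)CC(NC(=S)Nc2ccccc2)c2cc(Cl)ccc2O1`: 46000 nM
- Compound 3 `CCOC(=O)NC1CC(C)(C)Oc2ccc(Cl)cc21`: not yet measured

Compound 1 has one neighbour on these numbers, compound 2, and the two values lie within the scatter of each other. The change now under study is a group of 5 heavy atoms (3 carbon, 2 oxygen; no ring) in place of a group of 6 heavy atoms (4 carbon, 1 nitrogen, 1 sulfur; no ring), on an amine nitrogen. Within the data shown here, only one measured step bears on it, and only indirectly: a 1.2-fold lower number from compound 1 to compound 2 (0.09 log units; within the scatter). That step exchanges isopropyl for phenyl inside the departing group and leaves the rest of that group in place. Among the measured compounds shown here, no measured compound carries ethoxycarbonyl, so the evidence for this replacement is thin. On that limited basis, no step beyond the scatter is expected in this assay, and no direction is favoured. The estimated step is a 1.1-fold higher number from compound 1 to compound 3 (0.02 log units; within the scatter). For compound 3 the expected value is 60000 nM, with an estimated range of 25000 nM to 150000 nM.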

Compound 3, half-maximal inhibitory concentration: > 100000 nM
Compound 3 was reported as a limit; the forecaster's own chance of this, stated with the estimate: 25%; at least 1.6-fold (0.22 log units) between middle value and limit.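

In this assay, compound 3 gives > 100000 nM, which is a limit of the assay and not a number. Ethoxycarbonyl on the amine nitrogen gives an at least 1.7-fold higher number from compound 1 to compound 3 (0.24 log units; that floor lies within the scatter); the earlier exchange of isopropyl for phenyl had kept a measurable value, whereas this replacement of the whole group gives none, yet the floor of the step does not separate compound 3 from compound 1. The full size of the step cannot be read, because the value of compound 3 rests on a limit: the limit of > 100000 nM in this assay, at which 1 of the 3 values shown sits.

The compounds shown do not separate the oxygen of the carbonyl from the loss of the second nitrogen or from the ethyl part of the entering group. A urea on the same amine nitrogen, with oxygen in place of sulfur and the isopropyl kept, would test the first of these.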